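Propyl in Place of Benzyl on the Amide Nitrogen

The source may report more compounds than this note shows. Statements on the series, on what has been measured and on what is new or still open speak of the compounds shown alone.

Three measured compounds share one core and differ in the amide substituent and the aryl group: compound 1 `C=CC1=C(C(=O)Nc2ccccc2)C(c2ccc(Cl)c(Cl)c2)OC1`, compound 2 `C=CC1=C(C(=O)NC2CCCCC2)C(c2ccc(OC)cc2)OC1` and compound 3 `C=CC1=C(C(=O)NCc2ccccc2)C(c2ccc(Cl)c(Cl)c2)OC1`. In a functional assay on QGY7701 cells (Homo sapiens) for cytotoxicity, read by MTT assay, with a stated time of 24 h (on this read-out lower numbers stand for stronger inhibition and higher numbers for weaker inhibition), compound 1 gives only a limit, > 100000 nM. Compound 2 likewise reaches only a limit, > 100000 nM. Compound 3 also stands at a limit, > 100000 nM. Its place among the three therefore cannot be ranked, since all sit at the limit of > 100000 nM in this assay, at which 3 of the 3 values shown sit. For the measured compounds named here, the only measured step bearing on the next change, a step that the two limits leave unreadable from compound 1 to compound 3, has no readable size. Compound 4 `C=CC1=C(C(=O)NCCC)C(c2ccc(Cl)c(Cl)c2)OC1` differs from compound 3 by ethyl in place of phenyl on a saturated chain carbon bound to an amide-type nitrogen. No direction beyond scatter can be expected from these data. Compound 4 is therefore estimated at 150000 nM, within 50000 nM to 500000 nM, most likely again a limit. The expected step is a step that the limit leaves unreadable from compound 3 to compound 4.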

Compound 4, half-maximal inhibitory concentration: 31300 nM
Estimate against measurement, compound 4: 4.8-fold (0.68 log units) above; the measured number lies below the stated range.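

In this assay, the amide nitrogen proves to be a place where the substituent can move the read-out: propyl in place of benzyl gives an at least 3.1-fold lower number from compound 3 to compound 4 (0.50 log units; beyond the scatter), and propyl in place of phenyl gives an at least 3.1-fold lower number from compound 1 to compound 4 (0.50 log units; beyond the scatter). The earlier step from phenyl to benzyl cannot be read. Compound 4 alone gives a number rather than a limit: the limit of > 100000 nM in this assay, at which 3 of the 4 values shown sit.

On these data alone, whether a longer chain on the amide nitrogen lowers the number further stays open. So does whether a propyl chain ending in an amine or a carboxylic acid keeps this step.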